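This account rests on a few compounds, and the source may have more. Where it says the series, first, only, none or still open, it means among the compounds named here.

Measured so far:
- compound 1 `COCCCN1CCc2c(sc(NC(=O)Nc3ccc(Cl)cc3)c2C(N)=O)C1`: in a functional assay (strain AB) with Danio rerio as the target, read by microscopy, with a stated time of 1 h (a lower number here means that less compound is needed, a higher number that more compound is needed for the effect), compound 1 gives 2400 nM
- compound 2 `CCN1CCc2c(sc(NC(=O)Nc3ccc(Cl)cc3)c2C(=O)c2nnco2)C1`: for compound 2 this assay reports only a limit, > 25000 nM

Among the compounds with values here, compound 1 is therefore the only compound with an actual number in this assay; the one further value shown is a limit rather than a number, as the limit of > 25000 nM in this assay, at which 1 of the 2 values shown sits, records. Within the data shown here, no pair of measured compounds differs in just one place, so no measured step exists to lean on.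

Compound 3 `CC(C)(C)OC(=O)CCN1CCc2c(sc(NC(=O)Nc3ccc(Cl)cc3)c2C(N)=O)C1` has not yet been measured. It differs from compound 1 by tert-butoxycarbonyl in place of methoxymethyl on a saturated chain carbon, two bonds along the chain from an amine nitrogen in a ring. The shared core and the urea part stay untouched; only the chain on the ring amine nitrogen is altered.

Among the measured compounds shown here, with no measured step to guide the direction, the expected step is a 1.3-fold higher number from compound 1 to compound 3 (0.10 log units; within the scatter), which is meant to stay within the usual scatter of repeated measurements. Compound 3 is thus estimated at 3000 nM, with a range from 800 nM to 12000 nM expected to cover most repeat measurements.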

Compound 3, half-maximal effective concentration: 1100 nM
Beside the measured number, compound 3's estimate is 2.7-fold (0.44 log units) above it, within the range that was stated.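

In this assay, within the data shown here, the swap of methoxymethyl for tert-butoxycarbonyl gives a 2.2-fold lower number from compound 1 to compound 3 (0.34 log units; beyond the scatter) and is the first measured step on the chain carried by the ring amine nitrogen. A lower number means that less compound is needed for the effect, so this place accepts a group of 7 heavy atoms where a group of 3 stood, and the effect is modestly improved rather than lost. Nothing shown explains this gain, and the limit recorded for compound 2 does not help, since compound 2 differs from these two compounds in more than one place.

This one step adds heavy atoms and a carbonyl together, so it cannot say which of the two matters; a plain methyl ester or a longer ether chain at the same place would help to separate them. The compounds shown also leave open how a carboxylic acid or an amine at the end of this chain would compare with the tert-butoxycarbonyl group of compound 3.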